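This account rests on a few compounds, and the source may have more. Where it says the series, first, only, none or still open, it means among the compounds named here.

Measured so far:
compound 1 `O=C1OCCN1CCOc1nn(-c2ccccc2F)c2ccc(F)cc12` — 2480 mL/min/kg
compound 2 `O=C1NCCN1CCOc1nn(-c2ccc(F)cc2)c2ccc(F)cc12` — 217 mL/min/kg

In an ADME assay on liver for metabolic stability, with Liver microsome (Rattus norvegicus) as the target, using microsomes and NADPH, with a stated time of 30 min, tested at 0.5 uM (a lower number here means slower removal, a higher number faster removal of the compound), compound 1 gives 2480 mL/min/kg, the higher of the two numbers shown; the gap to compound 2 lies beyond the scatter. Compound 3 `O=c1[nH]ccn1CCOc1nn(-c2ccccc2F)c2ccc(F)cc12` is not yet measured. It differs from compound 1 in one place: a group of 6 heavy atoms (3 carbon, 2 nitrogen, 1 oxygen; one five-membered aromatic ring with 2 hetero atoms) in place of a group of 6 heavy atoms (3 carbon, 1 nitrogen, 2 oxygen; one five-membered non-aromatic ring with 2 hetero atoms), on a saturated chain carbon, two bonds along the chain from an oxygen on an aromatic ring. Compound 2, whose ring also bears a hydrogen on nitrogen, gives 217 mL/min/kg in this assay. On that basis compound 3 is expected to give a lower number, a step of a 3.1-fold lower number from compound 1 to compound 3 (0.49 log units; beyond the scatter), though its size is uncertain. Compound 3 is estimated at 800 mL/min/kg in this assay, in the range 200 mL/min/kg to 3000 mL/min/kg.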

Compound 3, clearance: 783 mL/min/kg
The estimate for compound 3 lay 1.0-fold (0.01 log units) above the measured number, within the range that was stated.
By their numbers in this assay, from the lowest: compound 2; then compound 3; then compound 1.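

On a saturated chain carbon, two bonds along the chain from an oxygen on an aromatic ring, replacing the 2-oxo-1,3-oxazolidin-3-yl group with the five-membered aromatic ring gives a 3.2-fold lower number from compound 1 to compound 3 (0.50 log units; beyond the scatter) in this assay. Among these compounds, this is the first comparison with the rest of the molecule held constant, and it shows that the number responds to this ring alone. Nothing available explains the drop. The compounds shown leave open how a morpholine or an open-chain urea would fare at this place. They also leave open what a longer chain carrying the same ring would give.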